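Adding Aminomethyl to a Polyamine Chain

The source may hold more compounds than are shown below. What is called first, only, known or untested is meant among the compounds shown, and "the series" means these compounds.

Compound 1 `CCNCCCCNCCCN` gives 40000 nM in the assay below
Compound 2 `CCCNCCCCNCCCN` gives 55000 nM in the same assay
Compound 3 `CCNCCCCNCCCCNCC` gives 350 nM in the same assay

All three numbers come from a functional assay on L1210 cells (Mus musculus) for inhibition, with a stated time of 96 h (on this read-out lower numbers stand for stronger inhibition and higher numbers for weaker inhibition), as the only read-out here. Compound 2 at 55000 nM sits level with compound 1 within the scatter, and both lie far above compound 3 in this read-out.

Compound 4 `CCCNCCCCNCCCCN` has not been measured yet. Its difference from compound 2 is aminomethyl in place of amino on a saturated chain carbon, three bonds along the chain from an amine nitrogen with aminomethyl in place of amino on a saturated chain carbon, three bonds along the chain from an amine nitrogen.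

Two measured steps offer guidance. Methyl in place of hydrogen on a saturated chain carbon, two bonds along the chain from an amine nitrogen, gave a 1.4-fold higher number from compound 1 to compound 2 (0.14 log units; within the scatter) and so offers little help. The closer guide is a 110-fold lower number from compound 1 to compound 3 (2.06 log units; beyond the scatter) which puts (ethylamino)methyl in place of amino at the same kind of place. That group carries an ethyl that aminomethyl lacks, and the data do not show how much of the large step goes with the ethyl. A drop in this assay is therefore expected, but a smaller one.

The expected change is a 6.9-fold lower number from compound 2 to compound 4 (0.84 log units; beyond the scatter) in this estimate. For compound 4 the estimated value is 8000 nM with an expected range from 1200 nM to 40000 nM in this read-out.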

Compound 4, half-maximal inhibitory concentration: 600 nM
Estimate against measurement, compound 4: 13-fold (1.12 log units) above; the whole stated range lies above it.
By their numbers in this assay, from the lowest: compounds 3 and 4 (each within the scatter of the next); then compounds 1 and 2 (each within the scatter of the next).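

In this assay, aminomethyl in place of amino, on a saturated chain carbon three bonds along the chain from an amine nitrogen, gives a 92-fold lower number from compound 2 to compound 4 (1.96 log units; beyond the scatter), although the entering group adds only a carbon and leaves the counts of hydrogen-bond donors and acceptors and the net charge unchanged. The earlier large step, a 110-fold lower number from compound 1 to compound 3 (2.06 log units; beyond the scatter), came with (ethylamino)methyl, so it could not show whether the ethyl was needed; this result shows that a large step at this kind of place occurs without any ethyl, at least on the chain of compound 2. No measurement shown here explains why so small a structural change goes with so large a step.

Going by these compounds, it remains open whether 2-aminoethyl or 3-aminopropyl at this place would go with a further step in the same direction, or whether the step would reverse as the chain grows longer. Also unresolved is whether the nitrogen of aminomethyl matters, a question that hydroxymethyl, with an oxygen in its place, or a plain ethyl group could help to answer.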